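The source may report more compounds than this note shows. Statements on the series, on what has been measured and on what is new or still open speak of the compounds shown alone.

Measured in an ADME assay on THP-1 cells (Homo sapiens) for cytotoxicity, read by flow cytometry and propidium iodide staining, with a stated time of 72 h; on this read-out lower numbers stand for stronger inhibition and higher numbers for weaker inhibition:
- compound 1 `Nc1ccc2oc(-c3ccc(F)cc3)cc(=O)c2c1`: 10000 nM
- compound 2 `Nc1ccc2oc(-c3ccccc3)c(O)c(=O)c2c1`: 27000 nM
- compound 3 `COc1ccc(-c2oc3ccc(N)cc3c(=O)c2O)cc1`: 29000 nM

Compound 3 at 29000 nM lies within the scatter of compound 2, and compound 1 shows a lower number, beyond the scatter. Next is compound 4 `Nc1ccc2oc(-c3ccc(F)cc3)c(O)c(=O)c2c1`, with fluoro in place of methoxy on an aromatic carbon. Among the compounds with values here, the only measured step at this place is a 1.1-fold higher number from compound 2 to compound 3 (0.03 log units; within the scatter), for methoxy in place of hydrogen. Compound 1 also carries fluoro but differs from compound 4 elsewhere on the shared core, so it gives only weak guidance. In this assay the expected step is a 1.2-fold lower number from compound 3 to compound 4 (0.08 log units; within the scatter), with no change beyond the scatter anticipated. For compound 4 the estimated value is 24000 nM, with an expected range of 12000 nM to 45000 nM.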

Compound 4, half-maximal inhibitory concentration: 4000 nM
Beside the measured number, compound 4's estimate is 6.0-fold (0.78 log units) above it; measured number below the stated range.
By their numbers in this assay, from the lowest: compound 4; then compound 1; then compounds 2 and 3 (each within the scatter of the next).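

At the aromatic carbon para to a large group, the identity of the substituent now matters in this assay: fluoro gives (a 7.3-fold lower number from compound 3 to compound 4 (0.86 log units; beyond the scatter)) against methoxy and (a 6.8-fold lower number from compound 2 to compound 4 (0.83 log units; beyond the scatter)) against hydrogen, whereas methoxy against hydrogen gave only (a 1.1-fold higher number from compound 2 to compound 3 (0.03 log units; within the scatter)). With fluoro held constant, adding hydroxy gives (a 2.5-fold lower number from compound 1 to compound 4 (0.40 log units; beyond the scatter)), so a second place on the shared core also moves the number.

On these data alone, whether chloro or an amine at the same carbon would track with fluoro remains open, as does whether fluoro gives a similar step without the hydroxy. Nothing measured here accounts for these steps.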